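Cytotoxicity of Three Amides and an Expected Fourth

The source may report more compounds than this note shows. Statements on the series, on what has been measured and on what is new or still open speak of the compounds shown alone.

Measured in an ADME assay on HepG2 cells (Homo sapiens) for cytotoxicity, with a stated time of 3 days; on this read-out lower numbers stand for higher toxicity in this test and higher numbers for lower toxicity in this test:
Compound 1 `O=C(CCSc1nnc(-c2ccncc2)s1)Nc1ccc(Cl)cc1` gives 7260 nM
Compound 2 `CC(Sc1nnc(-c2ccncc2)s1)C(=O)NCc1ccccc1Cl` gives > 50000 nM
Compound 3 `CC(Sc1nnc(-c2ccncc2)s1)C(=O)Nc1ccccc1` gives > 50000 nM

Compound 2 stands only at a limit of this assay, not at a number; this is the reading described by the limit of > 50000 nM in this assay, at which 2 of the 3 values shown sit. Compound 3 likewise gives only a limit in this assay. For the measured compounds named here, the one single-point step in hand, a step that the two limits leave unreadable from compound 2 to compound 3, therefore has no readable size. Compound 4 `CC(Sc1nnc(-c2ccncc2)s1)C(=O)Nc1c(Cl)cccc1Cl` differs from compound 2 as follows: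
2,6-dichlorophenyl in place of 2-chlorobenzyl on an amide-type nitrogen
Going by the values given here, no measured step bears directly on this change, and the step from compound 2 to compound 3 is itself unreadable. Compound 4 is accordingly expected to stay near the limit, with the step of an at least 1.1-fold lower number from compound 2 to compound 4 (0.04 log units; that floor lies within the scatter) estimated as having no clear direction. Compound 4 is estimated at 45000 nM, within the range 15000 nM to 100000 nM.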

Compound 4, half-maximal cytotoxic concentration: > 50000 nM
Compound 4: no number, only a limit (the forecaster's own chance of this, stated with the estimate: 65%); middle value at least 1.1-fold (0.04 log units) away from the limit.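

No step can be read among compound 2, compound 3 and compound 4, as each gives only a limit: the limit of > 50000 nM in this assay, at which 3 of the 4 values shown sit.

As far as these compounds go, whether the 2-chlorobenzyl, phenyl and 2,6-dichlorophenyl groups on the amide-type nitrogen differ at all in cytotoxicity remains open.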